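From an ethoxycarbonyl chain to a cyano chain

The source may hold more compounds than are shown below. What is called first, only, known or untested is meant among the compounds shown, and "the series" means these compounds.

Of the compounds shown here, three have been measured in a functional assay (blood) for inhibition, with Homo sapiens as the target; a lower number here means a stronger inhibitor, a higher number a weaker inhibitor. Compound 1 `CCOC(=O)CO/N=C(\C)c1ccc(Sc2cc(F)cc(C3CCOCC3)c2)cc1` gives 610 nM, the highest of the three numbers. Compound 2 `CO[C@]1(c2cc(F)cc(Sc3ccc(/C(C)=N/O)cc3)c2)CCO[C@@H](C)C1` differs from compound 1 in several places at once; compound 2 gives 40 nM. Compound 3 `C/C(=N\OCC(O)CO)c1ccc(S(=O)(=O)c2cccc(C3CCOCC3)c2)cc1` is again altered at more than one position relative to compound 1; compound 3 gives 160 nM. Among the compounds with values here, both of these lie well outside the scatter from compound 1, and no single-point step between any two measured compounds is available, so the only guidance for a fresh change at the oxime chain is the spread of these three numbers.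

Compound 4 `C/C(=N\OCC#N)c1ccc(Sc2cc(F)cc(C3CCOCC3)c2)cc1` keeps the core of compound 1 and changes only the end of that chain: cyano in place of ethoxycarbonyl on a saturated chain carbon bound to an oxygen on an unsaturated carbon. The ethoxycarbonyl group leaves and a cyano group enters on the saturated chain carbon bound to the oxime oxygen. Without a measured pair carrying this exact change, the step is expected to be modest and downward, a step of roughly a 1.5-fold lower number from compound 1 to compound 4 (0.18 log units; within the scatter) that may well remain within the scatter. Compound 4 is therefore estimated at 400 nM in this assay, with a range from 150 nM to 1100 nM.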

Compound 4, half-maximal inhibitory concentration: 20 nM
Compound 4: the middle estimate sits 20-fold (1.30 log units) above what was measured; measured number below the stated range.
By their numbers in this assay, from the lowest: compounds 4 and 2 (each within the scatter of the next); then compound 3; then compound 1.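

The pair gives this series its first single-place step: in this assay, cyano in place of ethoxycarbonyl on a saturated chain carbon bound to an oxygen on an unsaturated carbon brings a 31-fold lower number from compound 1 to compound 4 (1.48 log units; beyond the scatter) and counts as a large change. The earlier compounds shown here differed in several places at once and could not tie any shift to the end of this chain, whereas this pair shows that the end of the chain alone, with the rest of compound 1 kept, can carry a large shift in the number. The exchange also replaces a group of 5 heavy atoms with one of 2 and removes a carbonyl, but nothing shown here gives a measured reason for the step or separates these differences from one another.

It remains open whether the same step would follow from a carboxylic acid, a primary amide or a longer chain ending in cyano at this place, none of which appears among the compounds shown. Going by these compounds, it also remains open whether the exchange of ethoxycarbonyl for cyano would give a step of similar size on the core of compound 3.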